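This account rests on a few compounds, and the source may have more. Where it says the series, first, only, none or still open, it means among the compounds named here.

Compound 2 `O=C(Nc1nc2ccc(F)cc2s1)c1ccccc1C(=O)c1ccccc1` shares its core with compound 1 `O=C(Nc1nc2ccc(Cl)cc2s1)c1ccccc1C(=O)c1ccccc1`. In a functional assay on the whole organism with Mus musculus as the target, with a stated time of 4 h (on this read-out higher numbers stand for an effect only at larger amounts of compound and lower numbers for an effect already at smaller amounts), compound 1 gives 300 mg/kg, and compound 2 gives 300 mg/kg; the step of no change at the digits printed from compound 1 to compound 2 (within the scatter) falls within the scatter, so compound 2 stands level with compound 1. Compound 3 `COc1ccc2nc(NC(=O)c3ccccc3C(=O)c3ccccc3)sc2c1` differs from compound 2 by methoxy in place of fluoro on an aromatic carbon. Going by the values given here, no measured step replaces fluoro with methoxy, so only the flat pair of compounds 1 and 2 bears on this change, and that step showed nothing beyond the scatter. Compound 3 is therefore expected to stand at 300 mg/kg, between 150 mg/kg and 600 mg/kg, an estimated step of no change at the digits printed from compound 2 to compound 3 (within the scatter) that should stay within the scatter.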

Compound 3, minimum effective dose: 300 mg/kg
Estimate against measurement, compound 3: no gap at the digits printed; the measured number falls inside the stated range.
By their numbers in this assay, from the lowest: compounds 1, 2 and 3 (each within the scatter of the next).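

The steps in this assay read no change at the digits printed from compound 2 to compound 3 (within the scatter) and no change at the digits printed from compound 1 to compound 3 (within the scatter) and so show that the flat picture on this aromatic carbon is not confined to chloro and fluoro. Methoxy, which has two heavy atoms and a hydrogen-bond acceptor, fits the same picture in these three compounds. Nothing measured here explains this flat result. Still open, on these data alone, is whether an amine or a carboxylic acid on this carbon would shift the minimum effective dose. The compounds shown also leave open whether any group here gives an effect at smaller amounts.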